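Phenoxy in place of trifluoromethyl: expectation for compound 4

The source may report more compounds than this note shows. Statements on the series, on what has been measured and on what is new or still open speak of the compounds shown alone.

Compound 3 `C[C@H](NC(=O)C(=O)Nc1ccccc1C(F)(F)F)C(=O)N[C@@H](CC(=O)O)C(=O)COc1c(F)c(F)cc(F)c1F` gives 61 nM in a functional assay on Jurkat cells (Homo sapiens) for inhibition (a lower number here means a stronger inhibitor, a higher number a weaker inhibitor), the lowest of the three numbers shown, though all three sit within the scatter of one another. Compound 1 `C[C@H](NC(=O)C(=O)Nc1ccccc1Cl)C(=O)N[C@@H](CC(=O)O)C(=O)COc1c(F)c(F)cc(F)c1F` gives 64 nM and compound 2 `C[C@H](NC(=O)C(=O)Nc1ccccc1Br)C(=O)N[C@@H](CC(=O)O)C(=O)COc1c(F)c(F)cc(F)c1F` gives 75 nM. The measured steps of a 1.2-fold higher number from compound 1 to compound 2 (0.07 log units; within the scatter), a 1.0-fold lower number from compound 1 to compound 3 (0.02 log units; within the scatter) and a 1.2-fold lower number from compound 2 to compound 3 (0.09 log units; within the scatter) all stay within the scatter, so swapping this aromatic substituent among the three groups seen so far has not moved the read-out. Compound 4 `C[C@H](NC(=O)C(=O)Nc1ccccc1Oc1ccccc1)C(=O)N[C@@H](CC(=O)O)C(=O)COc1c(F)c(F)cc(F)c1F` carries phenoxy in place of trifluoromethyl on an aromatic carbon. These steps bear on the same position, yet none involves a group as large as phenoxy, so the expected step is a 1.5-fold higher number from compound 3 to compound 4 (0.17 log units; within the scatter), probably near the scatter toward a higher number. For compound 4 the estimated value is 90 nM, range 35 nM to 250 nM.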

Compound 4, half-maximal inhibitory concentration: 530 nM
Compound 4: the middle estimate sits 5.9-fold (0.77 log units) below what was measured, outside the stated range (above it).
By their numbers in this assay, from the lowest: compounds 3, 1 and 2 (each within the scatter of the next); then compound 4.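

This position accepts chloro, bromo and trifluoromethyl alike in this assay, but not phenoxy, which gives a clear rise (an 8.7-fold higher number from compound 3 to compound 4 (0.94 log units; beyond the scatter)), matched against the other two groups (a 7.1-fold higher number from compound 2 to compound 4 (0.85 log units; beyond the scatter); an 8.3-fold higher number from compound 1 to compound 4 (0.92 log units; beyond the scatter)). The flat read-out therefore holds only among the three groups without a ring; phenoxy, with its added aromatic ring, falls outside it. Nothing available accounts for this rise.

Still open, as far as these compounds go, is whether the aromatic ring or the ether oxygen of phenoxy goes with the rise. Phenyl, benzyl or methoxy at this position would separate the two.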